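The source may report more compounds than this note shows. Statements on the series, on what has been measured and on what is new or still open speak of the compounds shown alone.

Three compounds have been measured in a functional assay on DLD-1 cells (Homo sapiens) for cytotoxicity, read by colorimetric assay and MTT assay, with a stated time of 3 days, tested at 20 uM; on this read-out lower numbers stand for a stronger effect and higher numbers for a weaker effect at the one concentration tested:

compound 1, `O=C1COc2ccc(-c3[nH]c(-c4ccc(F)cc4)nc3-c3ccccc3)cc2N1`, 29.5%
compound 2, `O=C1COc2ccc(-c3nn(-c4ccc(Br)cc4)cc3-c3ccccc3)cc2N1`, 54.2%
compound 3, `O=C1COc2ccc(-c3nn(-c4ccc(Cl)cc4)cc3-c3ccccc3)cc2N1`, 47.1%

Compound 3 stands second highest of these three numbers. Its nearest neighbour is compound 2, whose number is higher by an amount that lies within the scatter, so the two cannot be told apart on these data; compound 1 lies furthest away, with a number lower by an amount beyond the scatter.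

Compound 4, `O=C1COc2ccc(-c3nn(-c4cc(Cl)cc(Cl)c4)cc3-c3ccccc3)cc2N1`, has not yet been measured. It differs from compound 3 in one place: 3,5-dichlorophenyl in place of 4-chlorophenyl on an aromatic nitrogen. Within the data shown here, only one measured step concerns the same ring, the swap of one halogen for another in a number 7.1 percentage points lower from compound 2 to compound 3 (within the scatter), and that step stayed within the scatter. Among the measured compounds shown here, no measured pair compares a single chloro with two chloro groups on that ring, so the change from compound 3 to compound 4 is not covered by a measured step, and no step beyond the scatter is expected in this assay. The estimate for compound 4 is 45%, with a range from 25% to 65%, which corresponds to an expected step of a number 2.1 percentage points lower from compound 3 to compound 4 (within the scatter).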

Compound 4, a percentage reported as activity, at one concentration (the size of the read-out at that concentration, not a potency): 52.2%
Estimate against measurement, compound 4: 7.2 percentage points below; the range from low to high includes it.
By their numbers in this assay, from the lowest: compound 1; then compounds 3, 4 and 2 (each within the scatter of the next).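

The earlier compounds shown here showed only one halogen swapped for another at the same ring position on the aromatic nitrogen, whereas the new result changes both the number of halogens and where they sit. In this assay, replacing 4-chlorophenyl with 3,5-dichlorophenyl gives a number 5.1 percentage points higher from compound 3 to compound 4 (within the scatter), and replacing 4-bromophenyl with 3,5-dichlorophenyl gives a number 2 percentage points lower from compound 2 to compound 4 (within the scatter), so the 4-bromophenyl, 4-chlorophenyl and 3,5-dichlorophenyl compounds cannot be told apart on this read-out at its single concentration. No measurement of any property of these groups is available to explain this result.

As far as these compounds go, all three of these rings carry only halogens, so it remains open whether an amine, a carboxylic acid or a methoxy group on the ring would give a step beyond the scatter. From the compounds shown here alone, it is also open what an unsubstituted phenyl, or a short alkyl chain in place of the ring, would do at this nitrogen.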